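This account rests on a few compounds, and the source may have more. Where it says the series, first, only, none or still open, it means among the compounds named here.

Compound 1 `S=C(N/N=C/c1ccc2ccccc2n1)Nc1ccc(Br)cc1`: 56800 nM
Compound 2 `N#Cc1ccc(NC(=S)N/N=C/c2ccc3ccccc3n2)cc1`: 20000 nM
Compound 3 `Fc1ccc(NC(=S)N/N=C/c2ccc3ccccc3n2)cc1`: 33200 nM

All three values come from a functional assay on HeLa cells (Homo sapiens) for antiproliferative activity, read by sulforhodamine B assay, with a stated time of 72 h; on this read-out higher numbers stand for weaker inhibition and lower numbers for stronger inhibition. The compounds share one core and differ only in the group on the outer benzene ring. Compound 3 holds the second highest of the three numbers, but both of its gaps fall within the scatter: a 1.7-fold lower number from compound 1 to compound 3 (0.23 log units; within the scatter) and a 1.7-fold higher number from compound 2 to compound 3 (0.22 log units; within the scatter). Compound 4 `COc1ccc(NC(=S)N/N=C/c2ccc3ccccc3n2)cc1` is not yet measured. It differs from compound 3 in one place: methoxy in place of fluoro on an aromatic carbon. Going by the values given here, no measured step swaps fluoro for methoxy. The nearest guides are the exchanges at the same position, a 1.7-fold lower number from compound 1 to compound 3 (0.23 log units; within the scatter) and a 1.7-fold higher number from compound 2 to compound 3 (0.22 log units; within the scatter), both within the scatter, and a 2.8-fold lower number from compound 1 to compound 2 (0.45 log units; beyond the scatter), which was modest. For compound 4 the expected step is a 1.0-fold lower number from compound 3 to compound 4 (0.02 log units; within the scatter), within the scatter. Compound 4 is therefore estimated at 32000 nM, with a range from 12000 nM to 85000 nM.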

Compound 4, half-maximal inhibitory concentration: 72600 nM
The estimate for compound 4 lay 2.3-fold (0.36 log units) below the measured number; the measured number falls inside the stated range.
By their numbers in this assay, from the lowest: compounds 2, 3, 1 and 4 (each within the scatter of the next, the first and the last beyond it).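

Among the earlier compounds, only the exchange of bromo for cyano moved the number beyond the scatter. Methoxy adds two more such steps, a 2.2-fold higher number from compound 3 to compound 4 (0.34 log units; beyond the scatter) and a 3.6-fold higher number from compound 2 to compound 4 (0.56 log units; beyond the scatter), while a 1.3-fold higher number from compound 1 to compound 4 (0.11 log units; within the scatter) stays within it, so this position does respond to the group it carries, though only modestly so far. Nothing measured here explains these steps. From the compounds shown here alone, whether an amine or a carboxylic acid at this position would stay within the same modest span remains open, as does the effect of a longer chain in place of methoxy.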